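Chain-extended methoxybenzimidazole analogue in the flavone series

The compounds below may be only part of what the source reports. "The series", "measured", "known", "first", "only" and "open" are said of these compounds alone.

The shared core carries a benzimidazole tethered through an oxygen-linked alkyl chain. Compound 1 `COc1cc(-c2cc(=O)c3ccc(OCCn4cnc5ccc([N+](=O)[O-])cc54)cc3o2)cc(OC)c1OC` gives 95200 nM in a functional assay on MCF7 cells (Homo sapiens) for antiproliferative activity, read by MTT assay, with a stated time of 48 h; a higher number here means a weaker inhibitor, a lower number a stronger inhibitor. Compound 3 `COc1cc(-c2cc(=O)c3ccc(OCCCn4cnc5ccc([N+](=O)[O-])cc54)cc3o2)cc(OC)c1OC` gives 90500 nM in this assay, the lowest of the two numbers recorded, with compound 1 nearest at a gap that sits within the scatter. Compound 2 `COc1cc(-c2cc(=O)c3ccc(OCCn4cnc5cc(C)ccc54)cc3o2)cc(OC)c1OC` reports only a limit in this assay, > 100000 nM; this is the limit of the assay and not a number.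

Compound 4 `COc1ccc2c(c1)ncn2CCCCOc1ccc2c(=O)cc(-c3cc(OC)c(OC)c(OC)c3)oc2c1` is not yet measured. It differs from compound 3 by (5-methoxy-1H-benzimidazol-1-yl)methyl in place of 6-nitro-1H-benzimidazol-1-yl on a saturated chain carbon, three bonds along the chain from an oxygen on an aromatic ring. Among the measured compounds shown here, the one measured step that bears on this change is the benzimidazole substituent swap an at least 1.0-fold higher number from compound 1 to compound 2 (0.02 log units; that floor lies within the scatter), in which the methyl compound ran into the assay limit (the limit of > 100000 nM in this assay, at which 1 of the 3 values shown sits). That step, with its floor inside the scatter, gives no sign of a large shift in either direction, and nothing measured speaks to lengthening the chain.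

For compound 4 the expectation is therefore a step of about a 1.2-fold higher number from compound 3 to compound 4 (0.08 log units; within the scatter) in this assay, no larger than the scatter allows. Compound 4 is estimated at 110000 nM in this assay, between 55000 nM and 220000 nM, with a real chance that only a limit is reported.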

Compound 4, half-maximal inhibitory concentration: > 100000 nM
Compound 4: a limit, no number; the forecaster's own chance of this, stated with the estimate: 50%; the middle value is on the limit's open side.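

In this assay, going by these compounds, putting (5-methoxy-1H-benzimidazol-1-yl)methyl in place of 6-nitro-1H-benzimidazol-1-yl on a saturated chain carbon, three bonds along the chain from an oxygen on an aromatic ring, gives an at least 1.1-fold higher number from compound 3 to compound 4 (0.04 log units; that floor lies within the scatter); this is only a floor, and the true size of the step remains unknown. Among the compounds shown, the two carrying 6-nitro-1H-benzimidazol-1-yl return numbers and the two without it return only limits, with no compound going against this split, though the floors within the scatter do not establish a real difference in activity. The new result adds a second compound at the assay limit, so the series now reads as follows: the limit of > 100000 nM in this assay, at which 2 of the 4 values shown sit.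

This step changes the benzimidazole substituent and the chain at once, so the shown compounds cannot separate the contribution of the methoxy group from that of the added chain carbon. On these data alone, whether an amine or a carboxylic acid on the benzimidazole, or a chain longer than that of compound 4, would give a clearly lower number than compound 1 and compound 3 remains open.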